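Swapping a butyl for a benzyl carbamate on a selenocyanate

The compounds below may be only part of what the source reports. "The series", "measured", "known", "first", "only" and "open" are said of these compounds alone.

Three aryl selenium compounds were tested in a functional assay on HT-29 cells (Homo sapiens) for cytotoxicity, read by MTT assay, with a stated time of 72 h; on this read-out lower numbers stand for stronger inhibition of growth and higher numbers for weaker inhibition of growth. Compound 1 `O=C(Nc1ccc([Se][Se]c2ccc(NC(=O)OCc3ccccc3)cc2)cc1)OCc1ccccc1` is a diselenide carrying two benzyl carbamate groups, and in this assay compound 1 gives 35400 nM. Compound 2 `CCCCOC(=O)Nc1ccc([Se]C#N)cc1` is a selenocyanate with a butyl carbamate, and compound 2 gives 31300 nM. Compound 3 `Cc1ccc(OC(=O)Nc2ccc([Se]C#N)cc2)cc1` is a selenocyanate with a tolyl carbamate, and compound 3 gives 38800 nM. Compound 2 sits at one end of these three numbers, but its gaps to compound 1 and to compound 3 both fall within the usual scatter, so the three cannot be told apart on this read-out.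

Compound 4 `N#C[Se]c1ccc(NC(=O)OCc2ccccc2)cc1` is not yet measured. It differs from compound 2 in one place: phenyl in place of propyl on a saturated chain carbon bound to an oxygen next to a carbonyl group. Since compound 1, compound 2 and compound 3 all land close together despite different carbamate groups, no step beyond the scatter is expected here. Compound 4 is estimated at 34000 nM, with a range from 18000 nM to 65000 nM. The expected step of a 1.1-fold higher number from compound 2 to compound 4 (0.04 log units; within the scatter) is therefore essentially flat.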

Compound 4, concentration for total growth inhibition: 41200 nM
For compound 4 the middle estimate is 1.2-fold (0.08 log units) below the measured one; low and high end bracket the measured number.
By their numbers in this assay, from the lowest: compounds 2, 1, 3 and 4 (each within the scatter of the next).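

For the compounds shown here, the pair compound 2 and compound 4 offers the first comparison here in which only one place changes, and this assay shows a 1.3-fold higher number from compound 2 to compound 4 (0.12 log units; within the scatter) when phenyl replaces propyl on a saturated chain carbon bound to an oxygen next to a carbonyl group. This place therefore accepts an aromatic ring of six carbons in place of a three-carbon chain with no change that this read-out can separate from repeat scatter. No measurement is available here that could explain this flat result.

Still open, going by these compounds, is whether an amine or a carboxylic acid at this place, or a longer chain such as octyl, would give a step beyond the scatter. Also open, on these data alone, is whether the same swap would stay as flat on a different core.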